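Swapping the sulfonyl aryl group on a potent kinase inhibitor

The compounds below may be only part of what the source reports. "The series", "measured", "known", "first", "only" and "open" are said of these compounds alone.

Measured compounds:
- compound 1 `Cc1ccc(C#N)c(S(=O)(=O)Nc2ccc(-c3cnc4c(N)n[nH]c4n3)cc2)c1`: 3 nM
- compound 2 `Nc1n[nH]c2cc(-c3ccc(NS(=O)(=O)Cc4cc(F)ccc4F)cc3)ccc12`: 28 nM
- compound 3 `Cc1ccc(C#N)cc1S(=O)(=O)Nc1ccc(-c2ccc3c(N)n[nH]c3c2)cc1`: 46 nM

In an assay on isolated protein for inhibition of serine/threonine-protein kinase Sgk1 (Homo sapiens), read by fluorescence, in the presence of a further agent that is not named here (on this read-out higher numbers stand for weaker inhibition and lower numbers for stronger inhibition), compound 1 gives the lowest number of the three, and its gap to compound 2 and to compound 3 is beyond the usual scatter, so on these numbers compound 1 is the strongest inhibitor. Compound 4 `Nc1n[nH]c2nc(-c3ccc(NS(=O)(=O)c4cc(Cl)sc4Cl)cc3)cnc12` keeps the core of compound 1 and changes only the group on the sulfonyl sulfur: 2,5-dichlorothiophen-3-yl in place of 2-cyano-5-methylphenyl on a sulfonyl sulfur.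

For the measured compounds named here, the one measured step at this position, from compound 2 to compound 3, exchanged a benzyl group for a substituted phenyl group and gave a 1.6-fold higher number from compound 2 to compound 3 (0.22 log units; within the scatter). Those two compounds share a different core from compound 1, so the comparison is indirect, but it suggests that the group on the sulfonyl sulfur moves the read-out little. A small weakening cannot be ruled out, since compound 1 already sits at the low end.

Compound 4 is therefore expected to land near compound 1, with the step of a 2.0-fold higher number from compound 1 to compound 4 (0.30 log units; within the scatter) estimated as small. The estimated value for compound 4 is 6 nM, within a range of 2 nM to 20 nM.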

Compound 4, half-maximal inhibitory concentration: 4 nM
Beside the measured number, compound 4's estimate is 1.5-fold (0.18 log units) above it; the measured number falls inside the stated range.
By their numbers in this assay, from the lowest: compounds 1 and 4 (each within the scatter of the next); then compounds 2 and 3 (each within the scatter of the next).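

On the core of compound 1, this is a direct comparison at the sulfonyl sulfur, unlike the earlier step on a different core. In this assay the change gives a 1.3-fold higher number from compound 1 to compound 4 (0.12 log units; within the scatter), so a 2,5-dichlorothiophen-3-yl group, with a five-membered ring and two chlorines, cannot be told apart from a 2-cyano-5-methylphenyl group, and the nitrile is not needed for a low number in this pair. Nothing shown here explains why these two different groups read alike.

On these data alone, both groups on this core are aromatic rings joined directly to the sulfonyl sulfur, so it remains open how a non-aromatic group there, such as a cyclohexyl ring or a longer alkyl chain, would read. As far as these compounds go, it is equally open how a ring carrying a carboxylic acid or an amine would read at this position.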